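The source may hold more compounds than are shown below. What is called first, only, known or untested is meant among the compounds shown, and "the series" means these compounds.

Measured compounds:
- compound 1 `CN1CCN(CCCCn2c3c(c4ccccc42)C(=O)c2c[n+]([O-])c4ccccc4c2C3=O)CC1`: 30 nM
- compound 2 `CC1(C)OC[C@H](Cn2cc(Cn3c4c(c5ccccc53)C(=O)c3c[n+]([O-])c5ccccc5c3C4=O)nn2)O1`: 180 nM

Going by the values given here, in a functional assay on A-375 cells (Homo sapiens) for cytotoxicity, read by MTT assay, with a stated time of 72 h (a lower number here means a stronger inhibitor, a higher number a weaker inhibitor), compound 1 gives 30 nM, the lowest of the two numbers so far. Among the compounds with values here, the nearest is compound 2, which in this assay gives 180 nM, a gap that lies beyond the scatter; no single-point step between the two is drawn, so what they show is only that compound 1 sits clearly below compound 2.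

Compound 3 `O=C1c2c[n+]([O-])c3ccccc3c2C(=O)c2[nH]c3ccccc3c21` is the unmeasured one. It differs from compound 1 in one place: hydrogen in place of 4-(4-methylpiperazin-1-yl)butyl on an aromatic nitrogen. Compound 3 thus carries nothing on that aromatic nitrogen, while compound 1 carries the 4-(4-methylpiperazin-1-yl)butyl there and compound 2 carries a different group at the same kind of position and sits higher.

Within the data shown here, with no measured step of the same kind to lean on, the expectation can only rest on the two values shown. Compound 3 is expected to come out weaker than compound 1, with a step of a 10-fold higher number from compound 1 to compound 3 (1.00 log units; beyond the scatter), most likely beyond the scatter. The estimate for compound 3 in this assay is 300 nM, within 60 nM to 1500 nM.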

Compound 3, half-maximal inhibitory concentration: 660 nM
For compound 3 the middle estimate is 2.2-fold (0.34 log units) below the measured one; measured number inside the range.
By their numbers in this assay, from the lowest: compound 1; then compound 2; then compound 3.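

In this assay, the aromatic nitrogen of the five-membered aromatic ring proves to be a place where the substituent matters greatly: putting hydrogen in place of 4-(4-methylpiperazin-1-yl)butyl gives a 22-fold higher number from compound 1 to compound 3 (1.34 log units; beyond the scatter), the first step measured at this position. The number does not vanish with the chain, however, since compound 3 still gives 660 nM, so the shared core without any substituent on that nitrogen keeps cytotoxic activity in the sub-micromolar range, and compound 2, with its different group at the same kind of position, gives 180 nM, a lower number than that of compound 3. No measurement at hand accounts for the size of this step.

Since the whole chain goes in a single change, the compounds shown do not separate what the butyl chain contributes from what the methylpiperazine ring contributes, and a plain butyl group or a shorter chain ending in the same ring would speak to that. On these data alone, it also stays open whether another terminal amine, such as a morpholine or a dimethylamino group, would hold the number of compound 1.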